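This account rests on a few compounds, and the source may have more. Where it says the series, first, only, none or still open, it means among the compounds named here.

Values in a functional assay on SMMC-7721 cells (Homo sapiens) for cytotoxicity, read by MTT assay, with a stated time of 24 h; a lower number here means a stronger inhibitor, a higher number a weaker inhibitor:
- Compound 1 `COc1ccc(/C=C2\CN(C)C/C(=C\c3cccnc3)C2=O)c(OC)c1OC`: 13700 nM
- Compound 2 `O=C1/C(=C/c2cccnc2)CNC/C1=C\c1ccccc1F`: > 20000 nM, a limit of the assay
- Compound 3 `O=C1/C(=C/c2ccncc2)CNC/C1=C\c1ccccc1F`: 18400 nM

Compound 3 at 18400 nM and compound 1 at 13700 nM lie within the scatter of each other.

Compound 4 `O=C1/C(=C/c2ccncc2)CN(S(=O)(=O)c2ccc(Br)cc2)C/C1=C\c1ccccc1F` is next: (4-bromophenyl)sulfonyl in place of hydrogen on an amine nitrogen in a ring, with (4-bromophenyl)sulfonyl in place of hydrogen on an amine nitrogen in a ring.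

For the measured compounds named here, the one measured step, an at least 1.0-fold lower number from compound 2 to compound 3 (0.03 log units; that floor lies within the scatter), concerns the pyridinyl group and does not touch this nitrogen, so it offers no direct guide. The addition is large, and a move towards a lower number, beyond the scatter, is expected only tentatively.

The expected step is a 3.1-fold lower number from compound 3 to compound 4 (0.49 log units; beyond the scatter).

For compound 4 the estimate is 6000 nM, with an expected range of 1500 nM to 20000 nM.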

Compound 4, half-maximal inhibitory concentration: 12600 nM
Compound 4: the middle estimate sits 2.1-fold (0.32 log units) below what was measured, within the range that was stated.
By their numbers in this assay, from the lowest: compounds 4, 1 and 3 (each within the scatter of the next). At a limit, above all of these: compound 2.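

In this assay the amine nitrogen in the ring takes (4-bromophenyl)sulfonyl in place of hydrogen, and the result is a 1.5-fold lower number from compound 3 to compound 4 (0.16 log units; within the scatter) for this change. This is the first step shown at this nitrogen, and an addition of 10 heavy atoms there leaves the two values within the scatter of each other. No measurement shown bears on the reason for this reading.

Open, on these data alone, is whether an acetyl group or a longer alkyl chain on this nitrogen would give a step beyond the scatter. The same question stands for a sulfonyl group carrying a carboxylic acid on its phenyl ring.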